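From benzamido to allylsulfanyl on a shared core

This account rests on a few compounds, and the source may have more. Where it says the series, first, only, none or still open, it means among the compounds named here.

Compound 1 `Cc1ccc(-c2nc(NC(=O)c3ccccc3)c3cc(Cl)ccc3n2)cc1` gives 16.2 ug/mL in a functional assay on HeLa cells (Homo sapiens) for antiproliferative activity, read by MTT assay, with a stated time of 48 h (on this read-out higher numbers stand for weaker inhibition and lower numbers for stronger inhibition), and stands level, within the scatter, with compound 3 `Cc1ccc(-c2nc3ccc(Cl)cc3c(=S)n2N)cc1` at 14 ug/mL on these numbers. For the measured compounds named here, compound 2 `Cc1ccc(-c2nc(NOC(=O)c3ccccc3)c3cc(Cl)ccc3n2)cc1` gives 5.18 ug/mL and the one measured step, a 3.1-fold lower number from compound 1 to compound 2 (0.50 log units; beyond the scatter) is modest. Compound 4 `C=CCSc1nc(-c2ccc(C)cc2)nc2ccc(Cl)cc12` carries allylsulfanyl in place of benzamido on an aromatic carbon next to the ring nitrogen. The measured step keeps a benzoyl-bearing group and so bears on this change only loosely, which leaves a small shift towards lower numbers as the expectation in this assay and nothing clearly beyond the scatter. The estimated change is a 1.5-fold lower number from compound 1 to compound 4 (0.17 log units; within the scatter) and is expected to stay small. Compound 4 is expected near 11 ug/mL (estimated range 4 ug/mL to 30 ug/mL).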

Compound 4, half-maximal inhibitory concentration: 9.66 ug/mL
Beside the measured number, compound 4's estimate is 1.1-fold (0.06 log units) above it, within the range that was stated.
By their numbers in this assay, from the lowest: compounds 2, 4, 3 and 1 (each within the scatter of the next, the first and the last beyond it).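

In this assay, a 1.7-fold lower number from compound 1 to compound 4 (0.22 log units; within the scatter) shows that on this aromatic carbon next to the ring nitrogen, benzamido can give way to allylsulfanyl, with no ring and no hydrogen-bond donor, and the number stays level. For the compounds shown here, the earlier step had kept a benzoyl-bearing group, so this is the first sign that neither that group's aromatic ring nor its hydrogen-bond donor is needed to hold the number here. No supporting evidence bears on this result. Going by these compounds, whether a simple amine or a longer sulfur-linked chain at this carbon would also stay level remains open.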